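Acetamido on the Fused Ring of Compound 2

The source may hold more compounds than are shown below. What is called first, only, known or untested is meant among the compounds shown, and "the series" means these compounds.

Of the compounds shown here, two have been measured in an assay on membranes from brain for binding affinity to Adrenergic receptor alpha-1 (Rattus norvegicus); a lower number here means a stronger inhibitor, a higher number a weaker inhibitor. Compound 1, `CS(=O)(=O)Nc1ccc2nc(CN3CCC(Cc4ccccc4)CC3)[nH]c2c1`, carries a methanesulfonamido group on its fused ring system and gives 1500 nM. Compound 2, `c1ccc(Oc2ccc(Cc3nc4ccccc4[nH]3)cc2)cc1`, has a bare fused ring system joined through a single carbon to a phenoxyphenyl group and gives 4200 nM. Of these two numbers, compound 2 stands at the higher one, and the gap to compound 1 lies beyond the usual scatter of such measurements.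

Compound 3, `CC(=O)Nc1ccc2[nH]c(Cc3ccc(Oc4ccccc4)cc3)nc2c1`, is compound 2 with one change: acetamido in place of hydrogen on an aromatic carbon. For the measured compounds named here, no measured pair shows this exact change, so the size of the step can only be anticipated. Going by the values given here, the only hint comes from compound 1, whose amide-like substituent on the fused ring goes with a value of 1500 nM, lower than that of compound 2. On that basis a modest move toward a lower number is expected for compound 3, on the order of a 2.1-fold lower number from compound 2 to compound 3 (0.32 log units; beyond the scatter), though a result within the scatter would not surprise. The estimate for compound 3 in this assay is therefore 2000 nM, with a plausible range from 700 nM to 6000 nM.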

Compound 3, half-maximal inhibitory concentration: 20000 nM
Estimate against measurement, compound 3: 10-fold (1.00 log units) below; the measured number lies above the stated range.
By their numbers in this assay, from the lowest: compound 1; then compound 2; then compound 3.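

In this assay, putting acetamido in place of hydrogen on this aromatic carbon of the fused ring system produces a 4.8-fold higher number from compound 2 to compound 3 (0.68 log units; beyond the scatter) and moves compound 3 toward weaker inhibition, a step that lies beyond the usual scatter. For the compounds shown here, this is the first direct reading of any change at this position, and it shows that adding this group to the core of compound 2 carries a clear cost in this assay. Compound 1 differs from compound 2 in more than one place, so its value cannot isolate the effect of a substituent here, and no measurement shown explains why the number rises.

Going by these compounds, it remains open whether the rise is specific to acetamido or would also appear with a simple amine, a carboxylic acid or a longer amide chain such as propionamido on the same carbon. It is also unknown whether a group of any of these kinds would give a step of similar size on the core of compound 1, where the surrounding structure is different.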